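Fluoro to Chloro on the Benzyl Group, Second Time

The source may report more compounds than this note shows. Statements on the series, on what has been measured and on what is new or still open speak of the compounds shown alone.

Compound 1 `COc1ccc(/C=C2\CN(C(=S)SCc3cn(Cc4ccccc4F)nn3)C/C(=C\c3ccc(OC)cc3)C2=O)cc1` gives 54500 nM in a functional assay on DU-145 cells (Homo sapiens) for cytotoxicity, read by MTT assay, with a stated time of 24 h; on this read-out lower numbers stand for stronger inhibition and higher numbers for weaker inhibition. Compound 3 `COc1ccc(/C=C2\CN(C(=S)SCc3cn(Cc4ccccc4Cl)nn3)C/C(=C\c3ccc(OC)cc3)C2=O)cc1` reaches only a limit of this assay, > 80000 nM. The change between them, (chloro in place of fluoro on an aromatic carbon), produced an at least 1.4-fold higher number from compound 1 to compound 3 (0.16 log units; that floor lies within the scatter), a reading bounded by the limit of > 80000 nM in this assay, at which 1 of the 3 values shown sits. Compound 2 `Cc1ccc(/C=C2\CN(Cc3cn(Cc4ccccc4F)nn3)C/C(=C\c3ccc(C)cc3)C2=O)cc1` has a different core; how the cores of compound 1 and compound 2 differ is not broken down here, and in this assay compound 2 gives 9500 nM. Compound 4 `Cc1ccc(/C=C2\CN(Cc3cn(Cc4ccccc4Cl)nn3)C/C(=C\c3ccc(C)cc3)C2=O)cc1` repeats the same change on the core of compound 2: chloro in place of fluoro on an aromatic carbon. Since the surroundings of the exchanged atom read the same in both cases, a step of similar direction is expected, a 1.7-fold higher number from compound 2 to compound 4 (0.23 log units; within the scatter), resting on the step from compound 1 to compound 3. Compound 4 is therefore estimated at 16000 nM, expected between 6000 nM and 45000 nM.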

Compound 4, half-maximal inhibitory concentration: 10500 nM
For compound 4 the middle estimate is 1.5-fold (0.18 log units) above the measured one, within the range that was stated.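

In this assay, chloro in place of fluoro on the core of compound 2 gives a 1.1-fold higher number from compound 2 to compound 4 (0.04 log units; within the scatter) and so compound 2 and compound 4 cannot be told apart. Whether the change acts alike on both cores cannot be settled: the same change on two cores in this assay, an at least 1.4-fold higher number (0.16 log units; that floor lies within the scatter) from compound 1 to compound 3 and a 1.1-fold higher number (0.04 log units; within the scatter) from compound 2 to compound 4; the limit leaves it open whether they differ. Compound 3 stands at a limit of the assay, > 80000 nM, which is not a number, so agreement between the two cores is neither shown nor ruled out.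

The compounds shown leave open what a bromo, a methoxy or an amine would do in the same place on the benzyl group. They also leave open how this change reads on any further core.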